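Moving from a nitrile to a bromo group

The compounds below may be only part of what the source reports. "The series", "measured", "known", "first", "only" and "open" are said of these compounds alone.

Measured in a functional assay on B16 cells (Mus musculus) for antiproliferative activity, read by MTT assay, with a stated time of 24 h; a higher number here means a weaker inhibitor, a lower number a stronger inhibitor:
- compound 1 `COc1cc(OC)c(-c2coc3cc(OCC(=O)c4cccc(C(F)(F)F)c4)ccc3c2=O)cc1OC`: > 10000 nM (a limit of the assay, not a number)
- compound 2 `COc1cc(OC)c(-c2coc3cc(OCc4ccc(Br)cc4)ccc3c2=O)cc1OC`: 1180 nM
- compound 3 `COc1cc(OC)c(-c2coc3cc(OCc4ccc(C#N)cc4)ccc3c2=O)cc1OC`: 7000 nM

Of the two results that are true numbers, the higher belongs to compound 3 at 7000 nM. Its nearest neighbour is the bromo analogue, and the measured difference is a 5.9-fold higher number from compound 2 to compound 3 (0.77 log units; beyond the scatter).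

The next compound to test is compound 4 `COc1cc(OC)c(-c2coc3cc(OCc4ccccc4Br)ccc3c2=O)cc1OC`, with 2-bromophenyl in place of 4-cyanophenyl on a saturated chain carbon bound to an oxygen on an aromatic ring.

The most relevant evidence is the swap of cyano and bromo on an aromatic carbon, which gave a 5.9-fold higher number from compound 2 to compound 3 (0.77 log units; beyond the scatter). The steps of an at least 8.4-fold lower number from compound 1 to compound 2 (0.92 log units; beyond the scatter) and an at least 1.4-fold lower number from compound 1 to compound 3 (0.15 log units; that floor lies within the scatter) help less, since both remove a carbonyl-bearing group that is absent from compound 4. Going by the values given here, no measured step shows what happens when 4-bromophenyl gives way to 2-bromophenyl, so the expectation is uncertain.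

Compound 4 shares a bromo substituent with compound 2 at 1180 nM, so a modest move to a lower number in this assay is expected, though probably not the full size of that swap. The expected step is a 2.8-fold lower number from compound 3 to compound 4 (0.45 log units; beyond the scatter). For compound 4, the estimated value is 2500 nM, with an expected range of 700 nM to 9000 nM.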

Compound 4, half-maximal inhibitory concentration: 8900 nM
Compound 4: the middle estimate sits 3.6-fold (0.55 log units) below what was measured, and the stated range covers the measured number.
By their numbers in this assay, from the lowest: compound 2; then compounds 3 and 4 (each within the scatter of the next). At a limit, above all of these: compound 1.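

In this assay, going by these compounds alone, keeping the bromo but changing 4-bromophenyl to 2-bromophenyl gives a 7.5-fold higher number from compound 2 to compound 4 (0.88 log units; beyond the scatter), so the result depends on where the bromo stands on the ring and not only on its presence, something the earlier compounds could not show. Putting 2-bromophenyl in place of 4-cyanophenyl gives a 1.3-fold higher number from compound 3 to compound 4 (0.10 log units; within the scatter), so the two cannot be told apart here, and the gain seen with compound 2 does not come with every bromo-bearing ring. The step of an at least 1.1-fold lower number from compound 1 to compound 4 (0.05 log units; that floor lies within the scatter) cannot be read, because its starting value is only a limit of the assay and not a number: the limit of > 10000 nM in this assay, at which 1 of the 4 values shown sits.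

Still open, going by these compounds, is whether a plain phenyl ring, or a chlorine, a methoxy group or an amine in place of the bromo on 4-bromophenyl, would match compound 2 or give a lower number. The compounds shown also leave open how a longer chain in place of the saturated chain carbon bound to the oxygen would fare with 4-bromophenyl.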